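The source may hold more compounds than are shown below. What is called first, only, known or untested is meant among the compounds shown, and "the series" means these compounds.

Two compounds built on one shared core were measured in a functional assay on HL-60 cells (Homo sapiens) for antiproliferative activity, with a stated time of 24 h; a higher number here means a weaker inhibitor, a lower number a stronger inhibitor. Compound 1 `NC(=O)c1c(NC(=O)c2ccccc2Cl)sc2c1CCN(C(=S)Nc1ccccc1Br)C2` gives 9090 nM, and compound 2 `NC(=O)c1c(NC(=O)c2ccccc2Cl)sc2c1CCN(C(=S)Nc1ccccc1C(F)(F)F)C2` gives 10600 nM. The change between them is trifluoromethyl in place of bromo on an aromatic carbon, and it made a step of a 1.2-fold higher number from compound 1 to compound 2 (0.07 log units; within the scatter).

Compound 3 `NC(=O)c1c(NC(=O)c2ccccc2Br)sc2c1CCN(C(=S)Nc1ccccc1F)C2` belongs to a second core, and how this core differs from that of compound 1 is not broken down here. In this assay compound 3 gives > 50000 nM, which is a limit of the assay rather than a number; it sits at the limit of > 50000 nM in this assay, at which 1 of the 3 values shown sits.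

Compound 4 `NC(=O)c1c(NC(=O)c2ccccc2C(F)(F)F)sc2c1CCN(C(=S)Nc1ccccc1F)C2` has not yet been measured. For the measured compounds named here, it differs from compound 3 by trifluoromethyl in place of bromo on an aromatic carbon, the same change as the one from compound 1 to compound 2. Because that earlier step was a 1.2-fold higher number from compound 1 to compound 2 (0.07 log units; within the scatter), the step from compound 3 to compound 4 is expected to be about a step that the limit leaves unreadable from compound 3 to compound 4. With compound 3 already at the limit, compound 4 is estimated to give 60000 nM, most likely reported only as a limit again, within a range from 30000 nM to 150000 nM.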

Compound 4, half-maximal inhibitory concentration: 23500 nM
Beside the measured number, compound 4's estimate is 2.6-fold (0.41 log units) above it; measured number below the stated range.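

In this assay, trifluoromethyl in place of bromo gives an at least 2.1-fold lower number from compound 3 to compound 4 (0.32 log units; beyond the scatter), whereas the same change on the other core gives a 1.2-fold higher number from compound 1 to compound 2 (0.07 log units; within the scatter). Compound 3 gives > 50000 nM, which is a limit of the assay and not a number: the limit of > 50000 nM in this assay, at which 1 of the 4 values shown sits. These results show that the change can go with a step beyond the scatter on one core and a step within the scatter on another, but they do not show whether its true size differs between the two cores: the same change on two cores in this assay, a 1.2-fold higher number (0.07 log units; within the scatter) from compound 1 to compound 2 and an at least 2.1-fold lower number (0.32 log units; beyond the scatter) from compound 3 to compound 4; the limit leaves it open whether they differ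

For the compounds shown here, each core contributes only one pair here, which is too little to set a rule for the series, and the true number for compound 3 remains unknown. On these data alone, it also remains open how the numbers would move with an amine or a carboxylic acid in place of trifluoromethyl on either core.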